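The source may report more compounds than this note shows. Statements on the series, on what has been measured and on what is new or still open speak of the compounds shown alone.

Compound 1 `COc1ncnc2c1c(-c1ccoc1)cn2[C@@H]1O[C@H](CO)[C@@H](O)[C@H]1O`, compound 2 `Cc1ncnc2c1c(-c1ccoc1)cn2[C@@H]1O[C@H](CO)[C@@H](O)[C@H]1O`, compound 3 `CSc1ncnc2c1c(-c1ccoc1)cn2[C@@H]1O[C@H](CO)[C@@H](O)[C@H]1O`.

In a functional assay on HL-60 cells (Homo sapiens) for antiproliferative activity, read by XTT assay, with a stated time of 72 h (on this read-out higher numbers stand for weaker inhibition and lower numbers for stronger inhibition), compound 1 gives 150 nM. Compound 2 reaches only a limit of the assay, > 15000 nM. On the numbers shown, compound 2 therefore stands at the limit of > 15000 nM in this assay, at which 1 of the 2 values shown sits, the weaker end of the two measured compounds. The change from compound 2 to compound 3 is methylsulfanyl in place of methyl on an aromatic carbon. For the measured compounds named here, the one measured step that bears on it is an at least 100-fold higher number from compound 1 to compound 2 (2.00 log units; beyond the scatter), where compound 1 carries the methoxy group. Compound 3 is expected to move back toward compound 1 by an at least 30-fold lower number from compound 2 to compound 3 (1.47 log units; beyond the scatter). Compound 3 is estimated at 500 nM, within 60 nM to 6000 nM.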

Compound 3, half-maximal inhibitory concentration: 360 nM
Compound 3: the middle estimate sits 1.4-fold (0.14 log units) above what was measured; measured number inside the range.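

In this assay, methylsulfanyl on this aromatic carbon recovers most of what the methyl group lacks: the result is an at least 41-fold lower number from compound 2 to compound 3 (1.61 log units; beyond the scatter). The comparison rests on a limit for compound 2: the limit of > 15000 nM in this assay, at which 1 of the 3 values shown sits. Methoxy is not the only group tolerated here, since methylsulfanyl stays close to it, with a 2.4-fold higher number from compound 1 to compound 3 (0.38 log units; beyond the scatter), a modest step that still leaves methoxy with the lower number.

From the compounds shown here alone, what remains open is whether an amine or a longer chain such as ethoxy at this position would also keep the activity. The compounds shown also cannot say whether the linking atom alone matters.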